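The source may hold more compounds than are shown below. What is called first, only, known or untested is meant among the compounds shown, and "the series" means these compounds.

Of the compounds shown here, three built on one shared core have been tested in an ADME assay on BCBL1 cells (Homo sapiens) for cytotoxicity, with a stated time of 7 days; on this read-out higher numbers stand for lower toxicity in this test and lower numbers for higher toxicity in this test. Compound 2 `Nc1nc(NC2CC2)c2ncn(/C=C3/CC3(CO)CO)c2n1` is the only one of the three for which an actual number is given: in this assay compound 2 gives 71500 nM. Compound 1 `CCCCCCCCOc1nc(N)nc2c1ncn2/C=C1/CC1(CO)CO` reaches only a limit of the test, and in this assay compound 1 gives > 20000 nM. Compound 3 `CCCCCOc1nc(N)nc2c1ncn2/C=C1/CC1(CO)CO` likewise reaches only a limit, and in this assay compound 3 gives > 20000 nM. Two of the three results thus sit at the limit of > 20000 nM in this assay, at which 2 of the 3 values shown sit. These limits leave every step between the measured compounds unreadable: a step that the limit leaves unreadable from compound 1 to compound 2, a step that the two limits leave unreadable from compound 1 to compound 3 and a step that the limit leaves unreadable from compound 2 to compound 3. All that can be said is that none of the three shows marked toxicity in this test.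

Compound 4 `CCCCCCSc1nc(N)nc2c1ncn2/C=C1/CC1(CO)CO` has not yet been measured. It differs from compound 2 in one place: hexylsulfanyl in place of cyclopropylamino on an aromatic carbon. The hexylsulfanyl chain of compound 4 resembles the octyloxy chain of compound 1 and the pentyloxy chain of compound 3 more than the cyclopropylamino group of compound 2, and both compound 1 and compound 3 gave only a limit. Among the compounds with values here, no measured step bears readably on this change, so no step beyond the usual scatter is expected in this assay in either direction, and the step of a 1.2-fold lower number from compound 2 to compound 4 (0.08 log units; within the scatter) is an estimate only. Compound 4 is therefore expected to give about 60000 nM in this assay, somewhere between 20000 nM and 150000 nM, with a fair chance that only a limit is reported.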

Compound 4, half-maximal cytotoxic concentration: > 20000 nM
Compound 4 gave a limit, no number (the forecaster's own chance of this, stated with the estimate: 65%); the middle value lies beyond the limit too.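

In this assay compound 4 gives > 20000 nM, which is a limit of the test and not a number. Within the data shown here, no step can therefore be read between compound 4 and compound 1, compound 2 or compound 3. The compounds shown leave open whether changing the group on this aromatic carbon of the shared core alters toxicity in this test at all.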